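The source may report more compounds than this note shows. Statements on the series, on what has been measured and on what is new or still open speak of the compounds shown alone.

Three compounds share one core and differ only in the group on a saturated chain carbon bound to an aromatic nitrogen. In a functional assay on CCRF-CEM cells (Homo sapiens) (on this read-out lower numbers stand for higher toxicity in this test and higher numbers for lower toxicity in this test), compound 1 `Cc1cn([C@@H]2O[C@H](CO[Si](C)(C)C(C)(C)C)[C@@]3(OS(=O)(=O)C=C3N)[C@H]2O[Si](C)(C)C(C)(C)C)c(=O)n(CC2CC2)c1=O`, with cyclopropyl there, gives 60400 nM. With hydroxymethyl in that place, compound 2 `Cc1cn([C@@H]2O[C@H](CO[Si](C)(C)C(C)(C)C)[C@@]3(OS(=O)(=O)C=C3N)[C@H]2O[Si](C)(C)C(C)(C)C)c(=O)n(CCO)c1=O` gives 11300 nM. Compound 3 `CNC(=O)Cn1c(=O)c(C)cn([C@@H]2O[C@H](CO[Si](C)(C)C(C)(C)C)[C@@]3(OS(=O)(=O)C=C3N)[C@H]2O[Si](C)(C)C(C)(C)C)c1=O`, with methylcarbamoyl, reaches only a limit of this assay and no number, >= 250000 nM.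

Compound 4 `Cc1cn([C@@H]2O[C@H](CO[Si](C)(C)C(C)(C)C)[C@@]3(OS(=O)(=O)C=C3N)[C@H]2O[Si](C)(C)C(C)(C)C)c(=O)n(C/C=C/CO)c1=O` starts from compound 3 and puts 3-hydroxyprop-1-en-1-yl in place of methylcarbamoyl on the same carbon: 3-hydroxyprop-1-en-1-yl in place of methylcarbamoyl on a saturated chain carbon bound to an aromatic nitrogen. The measured steps all concern this position. Hydroxymethyl in place of cyclopropyl gave a modest change, a 5.3-fold lower number from compound 1 to compound 2 (0.73 log units; beyond the scatter). Methylcarbamoyl in place of cyclopropyl gave an at least 4.1-fold higher number from compound 1 to compound 3 (0.61 log units; beyond the scatter), at least modest. Methylcarbamoyl in place of hydroxymethyl gave a large one, an at least 22-fold higher number from compound 2 to compound 3 (1.34 log units; beyond the scatter).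

The entering group carries a hydroxy end, as the hydroxymethyl of compound 2 does, so compound 2 at 11300 nM is the nearest guide, with compound 1 at 60400 nM as a second one. Losing the methylcarbamoyl should therefore undo much of the rise seen at compound 3, and a large move toward lower numbers is expected. The expected step is an at least 12-fold lower number from compound 3 to compound 4 (1.09 log units; beyond the scatter). For compound 4 the estimated value is 20000 nM, with an expected range from 6000 nM to 90000 nM.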

Compound 4, half-maximal cytotoxic concentration: 4410 nM
The estimate for compound 4 lay 4.5-fold (0.66 log units) above the measured number; measured number outside the range, below it.
By their numbers in this assay, from the lowest: compound 4; then compound 2; then compound 1. At a limit, above all of these: compound 3.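

In this assay, 3-hydroxyprop-1-en-1-yl in place of methylcarbamoyl gave an at least 56-fold lower number from compound 3 to compound 4 (1.75 log units; beyond the scatter), although the two groups match in heavy atoms, hydrogen-bond donors and acceptors, so those counts alone do not set the number at this position. The new group also goes further than either earlier replacement, with a 2.6-fold lower number from compound 2 to compound 4 (0.41 log units; beyond the scatter) and a 14-fold lower number from compound 1 to compound 4 (1.14 log units; beyond the scatter), which gives compound 4 the lowest number of the four and shows that the hydroxy-ended groups of compound 2 and compound 4 are not equivalent here. The first of these steps can be read only in one direction, as compound 3 stands at a limit and not at a number: the limit of >= 250000 nM in this assay, at which 1 of the 4 values shown sits.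

The compounds shown do not separate the hydroxy end of compound 4 from its double bond, a question that a saturated 4-hydroxybutyl group at the same place would address. They also leave open whether the hydroxy end matters at all, which an amine or a carboxylic acid at the end of the same chain would test.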